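Piperazine nitrogen substituent: ethyl toward neopentyl

A few compounds are considered here, and "the series" means these few. Any claim that something is new, unique, unknown or untested is made for them only; others in the source may bear on it.

Measured compounds in an assay on CHO-K1 cells for displacement of a labelled ligand from melanin-concentrating hormone receptor 1 (Homo sapiens), with a stated time of 2 h; on this read-out lower numbers stand for stronger inhibition and higher numbers for weaker inhibition:
compound 1 `Cc1nc(N2CCN(C3CCCC3)CC2)nc2ccc(NC(=O)COc3ccc(Cl)cc3)cc12`: 96 nM
compound 2 `CCN1CCN(c2nc(C)c3cc(NC(=O)COc4ccc(Cl)cc4)ccc3n2)CC1`: 690 nM

Among the compounds with values here, compound 2 carries the higher of the two numbers measured so far; its nearest neighbour is compound 1, and the step of a 7.2-fold higher number from compound 1 to compound 2 (0.86 log units; beyond the scatter) describes what separates them, namely ethyl in place of cyclopentyl on the amine nitrogen in the ring. Compound 3 `Cc1nc(N2CCN(CC(C)(C)C)CC2)nc2ccc(NC(=O)COc3ccc(Cl)cc3)cc12` has not been measured. Its difference from compound 2 is tert-butyl in place of methyl on a saturated chain carbon bound to an amine nitrogen in a ring, so the ethyl of compound 2 becomes neopentyl, and 4-ethylpiperazin-1-yl becomes 4-neopentylpiperazin-1-yl.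

Within the data shown here, only one measured step bears on this change: within this series the larger substituent on the ring amine nitrogen, cyclopentyl in compound 1, went with the lower number, and the smaller ethyl in compound 2 with the higher one, by the size of a 7.2-fold higher number from compound 1 to compound 2 (0.86 log units; beyond the scatter). Neopentyl is again a larger group on that nitrogen, though a chain rather than a ring, so the expectation is a lower number for compound 3 than for compound 2, smaller than a full return to compound 1. The expected step is a 3.5-fold lower number from compound 2 to compound 3 (0.54 log units; beyond the scatter). Compound 3 is therefore estimated at 200 nM, in the range 60 nM to 700 nM.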

Compound 3, half-maximal inhibitory concentration: 782 nM
Estimate against measurement, compound 3: 3.9-fold (0.59 log units) below; measured number outside the range, above it.
By their numbers in this assay, from the lowest: compound 1; then compounds 2 and 3 (each within the scatter of the next).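

In this assay, lengthening ethyl to neopentyl on the ring amine nitrogen gives a 1.1-fold higher number from compound 2 to compound 3 (0.05 log units; within the scatter), so this change, tert-butyl in place of methyl on a saturated chain carbon, leaves the read-out unmoved. Set against the cyclopentyl group, neopentyl gives an 8.1-fold higher number from compound 1 to compound 3 (0.91 log units; beyond the scatter), a step of the same order as the one printed for ethyl, which leaves compound 1 alone at the low end of these three and shows that a larger group on this nitrogen does not by itself bring the number down, with compound 3 going against the link that compounds 1 and 2 alone had suggested. Among these compounds the lower number goes with the one ring substituent and the higher numbers with the two open chains, but no measurement here accounts for that split.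

From the compounds shown here alone, with a single ring example, it remains open whether a cyclobutyl or cyclohexyl group would match cyclopentyl. Equally open, going by these compounds, is whether an unbranched chain such as n-butyl, or an isopropyl group, would sit with ethyl and neopentyl or with cyclopentyl.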